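Adding fluorine to an inactive phenoxy ketone

The compounds below may be only part of what the source reports. "The series", "measured", "known", "first", "only" and "open" are said of these compounds alone.

Measured in a functional assay with Homo sapiens as the target; on this read-out higher numbers stand for weaker inhibition and lower numbers for stronger inhibition:
- compound 1 `CC(C)[C@H](NC(=O)COc1cccc2ccccc12)C(=O)N[C@@H](CC(=O)O)C(=O)COc1ccccc1`: 11200 nM
- compound 2 `CC(C)[C@H](NC(=O)COc1cccc2ccccc12)C(=O)N[C@@H](CC(=O)O)C(=O)COc1c(F)cccc1F`: > 100000 nM

Compound 2 stands at > 100000 nM, which is a limit of the assay and not a number. Compound 3 `CC(C)[C@H](NC(=O)COc1cccc2ccccc12)C(=O)N[C@@H](CC(=O)O)C(=O)COc1c(F)c(F)c(F)c(F)c1F` carries 2,3,4,5,6-pentafluorophenyl in place of 2,6-difluorophenyl on an oxygen on a saturated carbon. Among the compounds with values here, one measured step bears on this change: an at least 8.9-fold higher number from compound 1 to compound 2 (0.95 log units; beyond the scatter), with 2,6-difluorophenyl replacing phenyl. That single step gives no sign of recovery, so no change beyond the scatter is expected in this assay. The estimate is a number no higher from compound 2 to compound 3 (the limit leaves the size open). For compound 3 the expected value is 100000 nM, within an estimated range of 20000 nM to 300000 nM.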

Compound 3, half-maximal inhibitory concentration: 8890 nM
The estimate for compound 3 lay 11-fold (1.05 log units) above the measured number, and the stated range ends above it.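

In this assay, the change to 2,3,4,5,6-pentafluorophenyl gives an at least 11-fold lower number from compound 2 to compound 3 (1.05 log units; beyond the scatter), so the loss seen with 2,6-difluorophenyl does not carry through to the pentafluorinated ring. Against phenyl, the same group gives a 1.3-fold lower number from compound 1 to compound 3 (0.10 log units; within the scatter), so adding fluorine at this place does not push the read-out in one direction across these compounds. The value of compound 2 is a limit of the assay and not a number: the limit of > 100000 nM in this assay, at which 1 of the 3 values shown sits.

From the compounds shown here alone, whether a phenyl carrying a single fluorine, a chlorine or a methoxy group here would behave like compound 2 or like compound 3 remains open.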